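The compounds below may be only part of what the source reports. "The series", "measured", "known", "first", "only" and "open" are said of these compounds alone.

Working notes on the series. The shared core of compound 1 `CCCCCCCCc1ccc(OCC(=O)Cn2nnc(-c3ccccc3)n2)cc1` carries the same octyl tail as compound 3 `CCCCCCCCc1ccc(OC(C)C(=O)Cn2nnc(-c3ccccc3)n2)cc1` and compound 2 `CCCCCCCCc1ccc(OCC(=O)Cn2nnnc2-c2cccc(S(=O)(=O)N(C)C)c2)cc1`. In an assay on microsomes from brain for inhibition of Fatty-acid amide hydrolase 1 (Rattus norvegicus), read by fluorescence and HPLC, with a stated time of 60 min (a lower number here means a stronger inhibitor, a higher number a weaker inhibitor), compound 1 gives 24 nM, compound 2 gives 1900 nM, and compound 3 gives 24 nM. Among the measured compounds shown here, the one single-point step measured so far, no change at the digits printed from compound 1 to compound 3 (within the scatter), therefore runs flat. Compound 3 stands with compound 1 at the low end of the three numbers; compound 2 sits well apart from both.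

Compound 4 `CC(Oc1ccc(Oc2ccc(Cl)cc2)cc1)C(=O)Cn1nnc(-c2ccccc2)n1` departs from compound 3 by 4-chlorophenoxy in place of octyl on an aromatic carbon. For the measured compounds named here, no measured step touches this position: the only step in hand changes the saturated chain carbon and leaves the tail untouched, and compound 2 differs from the others at the heterocycle, not at the tail. The exchange of the octyl chain for the 4-chlorophenoxy group is thus uncharted within the series, and the expectation can lean only on the fact that every measured compound carries the octyl tail. On that basis the estimate for compound 4 in this assay is a modest, uncertain loss, a 2.9-fold higher number from compound 3 to compound 4 (0.46 log units; beyond the scatter), giving an expected value of 70 nM with a range from 8 nM to 600 nM.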

Compound 4, half-maximal inhibitory concentration: 51 nM
Estimate against measurement, compound 4: 1.4-fold (0.14 log units) above; low and high end bracket the measured number.
By their numbers in this assay, from the lowest: compounds 1 and 3 (each within the scatter of the next); then compound 4; then compound 2.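

Among the compounds shown here, with a 2.1-fold higher number from compound 3 to compound 4 (0.33 log units; beyond the scatter), the first step at this position gives a modest but real rise in this assay, and compound 4 still gives 51 nM. The octyl tail, common to the three earlier compounds, is therefore not a requirement for a number of this order: on this aromatic carbon, para to a large group, 4-chlorophenoxy can stand in its place, with the same heavy-atom count but with a six-membered aromatic ring and a hydrogen-bond acceptor that octyl lacks. Nothing in hand explains the rise or says which part of the entering group accounts for it.

Going by these compounds, this single exchange changes the ring, the ether oxygen and the chlorine together, so the contribution of each stays unresolved, and how a plain phenoxy group, a longer chain such as decyl, or a carboxylic acid at this position would read remains open. Also open, on these data alone, is whether the flat methyl step, no change at the digits printed from compound 1 to compound 3 (within the scatter), carries over when 4-chlorophenoxy replaces octyl, since that step has been read only with the octyl tail.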